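Aryl swaps at the carbon between two ring nitrogens

The source may hold more compounds than are shown below. What is called first, only, known or untested is meant among the compounds shown, and "the series" means these compounds.

Working notes on the series. Three measured compounds share one core and differ mainly in the aromatic group on the carbon between two ring nitrogen atoms and in the group on the thiophene side. Compound 1 `Cc1ccc(-c2nc(N)c3cc(-c4ccccc4)sc3n2)o1` gives in a functional assay on CHO-K1 cells for antagonist activity at adenosine receptor A1 (Homo sapiens), read by a beta-galactosidase reporter and cAMP accumulation, with stated times of 15 min and 6 h (a lower number here means a stronger inhibitor, a higher number a weaker inhibitor), a value of 520 nM. Compound 2 `CC(C)c1ccc(-c2nc(N)c3cc(Cc4ccccc4)sc3n2)o1` gives in this assay a value of 283 nM. Compound 3 `COc1ccccc1Cc1cc2c(N)nc(-c3ccc(C(F)F)o3)nc2s1` gives in this assay a value of 516 nM. Compound 2 has the lowest number of the three, yet its gaps to compound 3 and to compound 1 both lie within the scatter, so no order among the three can be read from these numbers.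

Compound 4 `Cc1csc(-c2nc(N)c3cc(Cc4ccccc4)sc3n2)n1` is not yet measured. It differs from compound 2 in one place: 4-methyl-1,3-thiazol-2-yl in place of 5-isopropylfuran-2-yl on an aromatic carbon. Going by the values given here, no pair of measured compounds isolates this change, so no measured step exists for it. The three measured variations at this position all sit within the scatter of one another, which gives no basis for expecting a step beyond the scatter in either direction. The expected step is a 1.4-fold higher number from compound 2 to compound 4 (0.15 log units; within the scatter). For compound 4 the estimate in this assay is 400 nM, with a range from 120 nM to 1300 nM.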

Compound 4, inhibition constant: 1490 nM
Compound 4: the middle estimate sits 3.7-fold (0.57 log units) below what was measured; measured number above the stated range.
By their numbers in this assay, from the lowest: compounds 2, 3 and 1 (each within the scatter of the next); then compound 4.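

The position is not indifferent to the aromatic group it carries: in this assay, 4-methyl-1,3-thiazol-2-yl in place of 5-isopropylfuran-2-yl on the aromatic carbon between two ring nitrogen atoms gives a 5.3-fold higher number from compound 2 to compound 4 (0.72 log units; beyond the scatter). Going by these compounds alone, this is the first step that isolates a single change, since the three earlier compounds differ from one another in more than one place and could not tie any shift in the number to this position alone. The swap changes the ring and its alkyl group together, from a ring with 1 hetero atom to one with 2 and from isopropyl to methyl, and no supporting measurement separates these parts or accounts for the step.

Going by these compounds, it remains open whether the higher number follows the ring or the alkyl group, a question that 5-isopropyl-1,3-thiazol-2-yl or 5-methylfuran-2-yl on the core of compound 2 would address directly. Also open, on these data alone, is how other groups at this carbon, such as an unsubstituted pyridin-2-yl or phenyl ring, would stand against compound 2.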